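Cytotoxicity notes on the step from compound 3 to compound 4

This account rests on a few compounds, and the source may have more. Where it says the series, first, only, none or still open, it means among the compounds named here.

Measured so far:
Compound 1, `CCCN(Cc1ccc(OCCCCCC(=O)OCC)cc1)C(=O)c1ccc(Br)cc1`: in an ADME assay on Raji cells (Homo sapiens) for cytotoxicity, read by CellTiter-Glo and resazurin assay, with a stated time of 72 h (on this read-out higher numbers stand for an effect only at larger amounts of compound and lower numbers for an effect already at smaller amounts), compound 1 gives > 26000 nM, which is a limit of the assay.
Compound 2, `CCOC(=O)CCCCCOc1ccc(CNC(C)C)cc1`: in this assay compound 2 gives > 26000 nM, again a limit of the assay.
Compound 3, `CCCNCc1ccc(OCCCCCC(=O)OCC)cc1`: in this assay compound 3 gives > 26000 nM, also a limit of the assay.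

Compound 3 therefore stands at the same limit as the other two measured compounds, as the limit of > 26000 nM in this assay, at which 3 of the 3 values shown sit, records. The step that the two limits leave unreadable from compound 1 to compound 3 and the step that the two limits leave unreadable from compound 2 to compound 3 are both unreadable, since each joins two limits, so neither gives a size for any change at the amine nitrogen.

Compound 4, `CCOC(=O)CCCCCOc1ccc(C=O)cc1`, differs from compound 3 as follows: formyl in place of (propylamino)methyl on an aromatic carbon. For the measured compounds named here, no measured step bears on this change, and the three values of the series give no number to build from. Only the shared limit is known. It is expected that compound 4 again shows no effect within the tested range in this assay, estimated at 40000 nM (range 15000 nM to 120000 nM), an expected step that the limit leaves unreadable from compound 3 to compound 4, most likely reported as a limit once more.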

Compound 4, half-maximal effective concentration: > 26000 nM
Compound 4: no number, only a limit (the forecaster's own chance of this, stated with the estimate: 80%); the middle value is on the limit's open side.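

In this assay compound 4 gives > 26000 nM, a limit of the assay, so the steps to it from compound 2 and from compound 3 cannot be read. The compounds shown leave open what size any change in the series has, as all share one result: the limit of > 26000 nM in this assay, at which 4 of the 4 values shown sit.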